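Ethoxycarbonyl in place of methoxy: expectation for compound 3

The source may report more compounds than this note shows. Statements on the series, on what has been measured and on what is new or still open speak of the compounds shown alone.

In a functional assay on PC-3 cells (Homo sapiens) for inhibition, read by MTT assay, with a stated time of 48 h (on this read-out lower numbers stand for stronger inhibition and higher numbers for weaker inhibition), compound 1 (`COc1cc(Nc2nc(Nc3ccc(Cl)cc3)nnc2Cl)cc(OC)c1OC`) gives 9610 nM and compound 2 (`COc1ccc(Nc2nnc(Cl)c(Nc3cc(OC)c(OC)c(OC)c3)n2)cc1`) gives 13500 nM and so stands level with it. Going by the values given here, the one measured step (a 1.4-fold higher number from compound 1 to compound 2 (0.15 log units; within the scatter)) is methoxy in place of chloro on an aromatic carbon and stays within the scatter. Compound 3 (`CCOC(=O)c1ccc(Nc2nnc(Cl)c(Nc3cc(OC)c(OC)c(OC)c3)n2)cc1`) carries ethoxycarbonyl in place of methoxy on an aromatic carbon, para to a large group (ethoxycarbonyl in place of methoxy on an aromatic carbon). Among the compounds with values here, no compound with ethoxycarbonyl has been measured yet, so the evidence is thin. Within the data shown here, compound 2 remains the reference: on the size of the only measured step (a 1.4-fold higher number from compound 1 to compound 2 (0.15 log units; within the scatter)) no shift beyond the scatter is expected in this assay in either direction. The estimated step is small (a 1.1-fold lower number from compound 2 to compound 3 (0.05 log units; within the scatter)). For compound 3 the estimated value is 12000 nM (expected range 5000 nM to 30000 nM).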

Compound 3, half-maximal inhibitory concentration: 58500 nM
Beside the measured number, compound 3's estimate is 4.9-fold (0.69 log units) below it; measured number above the stated range.
By their numbers in this assay, from the lowest: compounds 1 and 2 (each within the scatter of the next); then compound 3.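

In this assay, this position on the aromatic ring, para to a large group, now shows that the substituent can matter: ethoxycarbonyl in place of methoxy gives a 4.3-fold higher number from compound 2 to compound 3 (0.64 log units; beyond the scatter) and ethoxycarbonyl in place of chloro gives a 6.1-fold higher number from compound 1 to compound 3 (0.78 log units; beyond the scatter) as the two steps to weaker inhibition. The earlier exchange of chloro for methoxy stayed within the scatter, so the three compounds separate ethoxycarbonyl from those two groups, and only within this small set. Nothing available here accounts for the shift.

From the compounds shown here alone, whether the weaker inhibition goes with the carbonyl or with the ethyl part of the ester stays open, and a carboxylic acid, a methyl ester or an amide at this position would separate the two. Also open, going by these compounds, is how a small amine or a hydroxyl group here would compare with chloro and methoxy.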